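Removing a Methyl Group: What to Expect for Compound 4

The source may hold more compounds than are shown below. What is called first, only, known or untested is meant among the compounds shown, and "the series" means these compounds.

Compound 1, `COc1cc(-c2nn(-c3cccc(NC(=O)Nc4cc(C(F)(F)F)cc(C(F)(F)F)c4)c3)cc2-c2ccncc2)ccc1Cl`, gives 144 nM in a functional assay on HOP-92 cells (Homo sapiens) for inhibition, read by sulforhodamine B assay, with a stated time of 48 h; a higher number here means a weaker inhibitor of growth, a lower number a stronger inhibitor of growth.
Compound 2, `O=C(Nc1cccc(-n2cc(-c3ccncc3)c(-c3ccc(Cl)c(O)c3)n2)c1)Nc1cc(C(F)(F)F)cc(C(F)(F)F)c1`, gives 344 nM in this assay.
Compound 3, `COc1cc(-c2nn(-c3cccc(NC(=O)Nc4ccc(Cl)c(C(F)(F)F)c4)c3)cc2-c2ccncc2)ccc1Cl`, gives 499 nM in this assay.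

Compound 1 and compound 2 share one core and differ in a single place: hydrogen in place of methyl on an oxygen on an aromatic ring. That change gave a 2.4-fold higher number from compound 1 to compound 2 (0.38 log units; beyond the scatter), so compound 2 is the weaker growth inhibitor of the pair.

Compound 3 carries a different urea end than compound 1; the difference between the two cores is not broken down here. Compound 3 gives the highest of the three numbers, though its gap to compound 2 lies within the scatter, while its gap to compound 1 lies beyond it.

Compound 4, `O=C(Nc1cccc(-n2cc(-c3ccncc3)c(-c3ccc(Cl)c(O)c3)n2)c1)Nc1ccc(Cl)c(C(F)(F)F)c1`, has not yet been measured. It stands to compound 3 exactly as compound 2 stands to compound 1: hydrogen in place of methyl on an oxygen on an aromatic ring. The place and its surroundings read the same in both pairs, so this is the same change made on a different core. Within the data shown here, the only guide to its effect is a 2.4-fold higher number from compound 1 to compound 2 (0.38 log units; beyond the scatter). A step of that size is expected from compound 3 to compound 4, a 2.3-fold higher number from compound 3 to compound 4 (0.36 log units; beyond the scatter). On that basis compound 4 is expected to give 1150 nM in this assay, with a likely range from 450 nM to 2900 nM.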

Compound 4, concentration for 50% growth inhibition: 376 nM
For compound 4 the middle estimate is 3.1-fold (0.49 log units) above the measured one, outside the stated range (below it).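

Replacing methoxy with hydroxy did not behave the same way on both cores: on the core of compound 3 the change gave a 1.3-fold lower number from compound 3 to compound 4 (0.12 log units; within the scatter), so this assay does not separate these two compounds, whereas on the core of compound 1 the same change gave a real loss of growth inhibition. The gap between the two results is larger than repeated measurements would be expected to produce: the same change on two cores in this assay, a 2.4-fold higher number (0.38 log units; beyond the scatter) from compound 1 to compound 2 and a 1.3-fold lower number (0.12 log units; within the scatter) from compound 3 to compound 4, 3.2-fold (0.50 log units) apart, beyond the scatter of two such steps. This shows that, for these two cores, which differ at the urea end, the step seen on one core was not a reliable guide to the step on the other, but two pairs cannot show why the results differ or how the change would behave with any other urea end.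

The compounds shown leave open what would happen with an ethyl group or a longer chain on that oxygen, or with an amine in place of the hydroxy, on either core. They also leave open whether a third urea end, for example one carrying a nitrile, would follow the pair of compound 1 and compound 2, the pair of compound 3 and compound 4, or neither.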